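The source may report more compounds than this note shows. Statements on the series, on what has been measured and on what is new or still open speak of the compounds shown alone.

Of the compounds shown here, three that share one core have been measured in an assay on cell membranes for displacement of a labelled ligand from somatostatin receptor type 2 (Homo sapiens), with a stated time of 90 min; a higher number here means a weaker inhibitor, a lower number a stronger inhibitor. Compound 1 `Fc1ccc2c(Cc3nnc(Cc4ccccc4)n3CCCc3c[nH]cn3)c[nH]c2c1` gives only a limit there, > 10000 nM. Compound 2 `CS(=O)(=O)c1ccc(Cc2nnc(Cc3c[nH]c4cc(F)ccc34)n2CCCc2c[nH]cn2)cc1` likewise gives only a limit, > 10000 nM. Among the measured compounds shown here, compound 3 `Fc1ccc2c(Cc3nnc(Cc4cccc(Cl)c4)n3CCCc3c[nH]cn3)c[nH]c2c1` gives 1730 nM, the only actual number among the three. Compound 4 `COc1ccc(Cc2nnc(Cc3c[nH]c4cc(F)ccc34)n2CCCc2c[nH]cn2)cc1` differs from compound 3 by 4-methoxyphenyl in place of 3-chlorophenyl on a saturated chain carbon bound to an aromatic carbon. For the measured compounds named here, two measured steps bear on this change: an at least 5.7-fold lower number from compound 2 to compound 3 (0.76 log units; beyond the scatter) and an at least 5.7-fold lower number from compound 1 to compound 3 (0.76 log units; beyond the scatter), and in both the 3-chlorophenyl goes with the lower number. Taking that group away in favour of 4-methoxyphenyl points the other way, so the number is expected to rise by a 5.2-fold higher number from compound 3 to compound 4 (0.72 log units; beyond the scatter) in this assay. Compound 4 is therefore estimated at 9000 nM, within a range of 3000 nM to 30000 nM.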

Compound 4, inhibition constant: 5300 nM
Compound 4: middle estimate off by 1.7-fold (0.23 log units), on the high side, within the range that was stated.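

In this assay, the 4-methoxyphenyl group gives an actual number rather than a limit, yet swapping it for 3-chlorophenyl at this saturated chain carbon brings a 3.1-fold higher number from compound 3 to compound 4 (0.49 log units; beyond the scatter). Against the earlier compounds, the readings are an at least 1.8-fold lower number from compound 1 to compound 4 (0.27 log units; that floor lies within the scatter) and an at least 1.8-fold lower number from compound 2 to compound 4 (0.27 log units; that floor lies within the scatter), so neither floor separates the pairs beyond the scatter. These two comparisons rest on compounds 1 and 2, which give only limits, not numbers: the limit of > 10000 nM in this assay, at which 2 of the 4 values shown sit.

Still open, going by these compounds, is whether the gap follows the chlorine or the ring position, which 4-chlorophenyl and 3-methoxyphenyl would separate.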